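Methyl on the Aromatic Carbon of Compound 1

A few compounds are considered here, and "the series" means these few. Any claim that something is new, unique, unknown or untested is made for them only; others in the source may bear on it.

Measured in a functional assay on HeLa cells (Homo sapiens) for antiproliferative activity, read by resazurin assay (a lower number here means a stronger inhibitor, a higher number a weaker inhibitor), are these compounds:
compound 1 `CCSC(=S)SCC(=O)c1ccccc1` gives 5010 nM here
compound 2 `CCSC(=S)SCC(=O)c1ccc(NS(C)(=O)=O)cc1` gives 39800 nM here
compound 3 `CCSC(=S)SCC(=O)c1ccc(OC)cc1` gives 2510 nM here

Among these three, compound 1 with 5010 nM has compound 3 as its nearest neighbour and compound 2 as its furthest. Compound 4 `CCSC(=S)SCC(=O)c1ccccc1C` has not yet been measured. Its change from compound 1 is methyl in place of hydrogen on an aromatic carbon, ortho to a group of 9 heavy atoms, counted in full as methyl in place of hydrogen on an aromatic carbon in the structures. Among the measured compounds shown here, two measured steps bear on this, as each also replaces hydrogen on an aromatic carbon. Methoxy gave a 2.0-fold lower number from compound 1 to compound 3 (0.30 log units; within the scatter) and methanesulfonamido gave a 7.9-fold higher number from compound 1 to compound 2 (0.90 log units; beyond the scatter) in the same test. Neither step introduces a methyl, so the guide is indirect. The account leans on the smaller step, a 2.0-fold lower number from compound 1 to compound 3 (0.30 log units; within the scatter) as its basis, and no step beyond the scatter is expected in this assay for this change. The estimated step is a 1.3-fold lower number from compound 1 to compound 4 (0.10 log units; within the scatter) in size. For compound 4 the expected value is 4000 nM with an estimated range from 1500 nM to 11000 nM in this test.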

Compound 4, half-maximal inhibitory concentration: 10000 nM
Estimate against measurement, compound 4: 2.5-fold (0.40 log units) below; the measured number falls inside the stated range.
By their numbers in this assay, from the lowest: compounds 3, 1 and 4 (each within the scatter of the next, the first and the last beyond it); then compound 2.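

In this assay, among the compounds shown here, methyl ortho to a group of 9 heavy atoms gives a 2.0-fold higher number from compound 1 to compound 4 (0.30 log units; within the scatter), so this single added carbon on the ring of compound 1 yields no step that can be told from the scatter. This is the first group shown at this place, and it shows that the place accepts methyl without a step beyond the scatter, although one example cannot define a trend. No measured evidence accounts for the result or explains why compound 4 stays within the scatter of compound 1.

The compounds shown leave open whether a group other than methyl at this place would stay within the scatter. An amine or a carboxylic acid on this same aromatic carbon, for instance, might give a step beyond it.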